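Urea aryl swap on the shared core: compound 4

The source may report more compounds than this note shows. Statements on the series, on what has been measured and on what is new or still open speak of the compounds shown alone.

Compound 1 `COc1cc2nccc(Oc3ccc4c(NC(=O)Nc5ccc(C(F)(F)F)cc5Cl)nn(C)c4c3)c2cc1OC` carries a (2-chloro-4-(trifluoromethyl)phenyl)amino group on the carbonyl carbon of the shared core. In a functional assay on HUVEC cells (Homo sapiens) for inhibition, with stated times of 2 h and 72 h (on this read-out lower numbers stand for stronger inhibition and higher numbers for weaker inhibition), compound 1 gives > 1000 nM, which is a limit of the assay and not a number. Compound 2 `COc1cc2nccc(Oc3ccc4c(NC(=O)C5CC5)nn(C)c4c3)c2cc1OC` has cyclopropyl in place of that group; in this assay compound 2 gives > 1000 nM, again a limit. Compound 3 `COc1ccc(C(=O)Nc2nn(C)c3cc(Oc4ccnc5cc(OC)c(OC)cc45)ccc23)cc1` has 4-methoxyphenyl on the carbonyl carbon; in this assay compound 3 gives > 1000 nM, also a limit. The steps a step that the two limits leave unreadable from compound 1 to compound 2, a step that the two limits leave unreadable from compound 1 to compound 3 and a step that the two limits leave unreadable from compound 2 to compound 3 cannot be read, since (the limit of > 1000 nM in this assay, at which 3 of the 3 values shown sit). Compound 4 `COc1cc2nccc(Oc3ccc4c(NC(=O)Nc5ccc(C)cc5)nn(C)c4c3)c2cc1OC` differs from compound 1 thus: 4-methylphenyl in place of 2-chloro-4-(trifluoromethyl)phenyl on an amide-type nitrogen. No measured step covers this change, and every measured value sits at the limit, so the size of the step from compound 1 to compound 4 cannot be anticipated from the numbers shown. Compound 4 is expected to stay near or beyond the limit, with an estimated step that the limit leaves unreadable from compound 1 to compound 4. The estimate for compound 4 in this assay is 2000 nM, within the range 500 nM to 10000 nM.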

Compound 4, half-maximal inhibitory concentration: > 1000 nM
Compound 4 was reported as a limit; the forecaster's own chance of this, stated with the estimate: 70%; the middle value does not contradict the limit.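

Compound 4 also sits at a limit of the assay, so its steps with compound 1, compound 2 and compound 3 cannot be read: the limit of > 1000 nM in this assay, at which 4 of the 4 values shown sit. The compounds shown leave open whether any of these groups on the carbonyl carbon changes inhibition in this assay.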